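The source may report more compounds than this note shows. Statements on the series, on what has been measured and on what is new or still open speak of the compounds shown alone.

Compound 3 `COc1cc(NC(C)CCCNC(=O)Nc2ccc(O)cc2)c2ncccc2c1` gives 23000 nM in a functional assay on CCRF-CEM cells (Homo sapiens) for inhibition, read by MTT assay, with a stated time of 72 h (a lower number here means a stronger inhibitor, a higher number a weaker inhibitor), the second highest of the three numbers: compound 2 `COc1cc(NC(C)CCCNC(=O)Nc2ccc(C(F)(F)F)cc2)c2ncccc2c1` gives 14000 nM, while compound 1 `COc1cc(NC(C)CCCNC(=O)NNC(=O)Nc2ccc(Br)cc2)c2ncccc2c1` gives 110000 nM. Compound 4 `COc1cc(NC(C)CCCNC(=O)NNC(=O)Nc2ccc(O)cc2)c2ncccc2c1` differs from compound 3 as follows: ((4-hydroxyphenyl)carbamoyl)amino in place of 4-hydroxyphenyl on an amide-type nitrogen. The step that bears on this runs the opposite way, with a 4.8-fold lower number from compound 1 to compound 3 (0.68 log units; beyond the scatter), and the step with a 7.9-fold lower number from compound 1 to compound 2 (0.90 log units; beyond the scatter) points the same way; the comparison with a 1.6-fold higher number from compound 2 to compound 3 (0.22 log units; within the scatter) suggests that the hydroxy and bromo versions behave alike. Reversing that change is therefore expected to raise the number beyond the scatter, with a 3.9-fold higher number from compound 3 to compound 4 (0.59 log units; beyond the scatter). Compound 4 is estimated at 90000 nM, within a range from 30000 nM to 250000 nM.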

Compound 4, half-maximal inhibitory concentration: 111000 nM
Compound 4: the middle estimate sits 1.2-fold (0.09 log units) below what was measured, and the stated range covers the measured number.
By their numbers in this assay, from the lowest: compounds 2 and 3 (each within the scatter of the next); then compounds 1 and 4 (each within the scatter of the next).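

In this assay, ((4-hydroxyphenyl)carbamoyl)amino on the amide-type nitrogen gives a weaker inhibitor than 4-hydroxyphenyl, with a 4.8-fold higher number from compound 3 to compound 4 (0.68 log units; beyond the scatter), and than 4-(trifluoromethyl)phenyl, with a 7.9-fold higher number from compound 2 to compound 4 (0.90 log units; beyond the scatter). Within the carbamoylamino pair, hydroxy in place of bromo on the aromatic carbon stays within the scatter, with a 1.0-fold higher number from compound 1 to compound 4 (0.00 log units; within the scatter), so here the added carbamoylamino unit counts for more than that ring group. Nothing at hand explains this loss. The compounds shown leave open whether an amine or a carboxylic acid on that aromatic carbon would change the number in either pair.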